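Amide in place of propyl chain on the ring nitrogen

A few compounds are considered here, and "the series" means these few. Any claim that something is new, unique, unknown or untested is made for them only; others in the source may bear on it.

Going by the values given here, compound 1 `CN(C)C12CCN(CCCN3CCCCC3)C(C(c3ccccc3)C1)C(c1ccccc1)C2` gives 58400 nM in an ADME assay on L6 cells (Rattus norvegicus) for cytotoxicity (on this read-out lower numbers stand for stronger inhibition and higher numbers for weaker inhibition), and stands second highest of the three numbers so far: compound 2 `c1ccc(C2CC3(N4CCCCC4)CCN(CCCN4CCCCC4)C2C(c2ccccc2)C3)cc1` gives 138000 nM and compound 3 `CN(C)C12CC(NCCN3CCCC3)C(C(c3ccccc3)C1)C(c1ccccc1)C2` gives 22800 nM. Among the compounds with values here, the one step with a single change, a 2.4-fold higher number from compound 1 to compound 2 (0.37 log units; beyond the scatter), concerns a replacement on a saturated ring carbon. Compound 4 `CN(C)C12CCN(C(=O)CCN3CCCCC3)C(C(c3ccccc3)C1)C(c1ccccc1)C2` changes a different position: (2-(piperidin-1-yl)ethyl)carbonyl in place of 3-(piperidin-1-yl)propyl on an amine nitrogen in a ring. Within the data shown here, no measured step touches this ring nitrogen, so the single known step only shows that changes elsewhere in the core move this assay modestly. The expected step of a 1.0-fold lower number from compound 1 to compound 4 (0.00 log units; within the scatter) is therefore none beyond the scatter, with a wide band. Compound 4 is estimated at 58000 nM, between 22000 nM and 150000 nM.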

Compound 4, half-maximal inhibitory concentration: 128000 nM
Beside the measured number, compound 4's estimate is 2.2-fold (0.34 log units) below it; the measured number falls inside the stated range.
By their numbers in this assay, from the lowest: compound 3; then compound 1; then compounds 4 and 2 (each within the scatter of the next).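

In this assay, the amine nitrogen in a ring is shown for the first time to respond to substitution: (2-(piperidin-1-yl)ethyl)carbonyl in place of 3-(piperidin-1-yl)propyl gives a 2.2-fold higher number from compound 1 to compound 4 (0.34 log units; beyond the scatter). The step is modest, but this position is not neutral in this read-out. No supporting data bear on what underlies the shift.

Open, as far as these compounds go, is whether a sulfonyl link or a longer chain on this nitrogen would move the number the same way. Also open, from the compounds shown here alone, is whether the step carries over to the piperidin-1-yl core of compound 2.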